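From acetamido to (cyclopropylcarbonyl)amino

The source may report more compounds than this note shows. Statements on the series, on what has been measured and on what is new or still open speak of the compounds shown alone.

- Compound 1 `O=C(Nc1n[nH]c2cc(-c3cn([C@@H]4CN[C@H](C(=O)Nc5ccc(Cl)c(C(F)(F)F)c5)C4)nn3)ccc12)C1CC1`: 5200 nM
- Compound 2 `CC(=O)Nc1n[nH]c2cc(-c3cn([C@@H]4CN[C@H](C(=O)Nc5ccc(Cl)cc5Cl)C4)nn3)ccc12`: 2090 nM

In a functional assay on K562 cells (Homo sapiens) for inhibition, read by MTT assay, with a stated time of 48 h (on this read-out higher numbers stand for weaker inhibition and lower numbers for stronger inhibition), compound 2 gives the lower of the two numbers, a gap to compound 1 that lies beyond the scatter. Compound 3 `O=C(Nc1n[nH]c2cc(-c3cn([C@@H]4CN[C@H](C(=O)Nc5ccc(Cl)cc5Cl)C4)nn3)ccc12)C1CC1` differs from compound 2 by cyclopropyl in place of methyl on a carbonyl carbon, with cyclopropyl in place of methyl on a carbonyl carbon. Among the compounds with values here, no measured pair shows this change alone, although compound 1, at 5200 nM, also carries cyclopropyl there. A small rise in the number in this assay is therefore expected, possibly none beyond the scatter. The expected change is a 1.3-fold higher number from compound 2 to compound 3 (0.13 log units; within the scatter). For compound 3, the estimate is 2800 nM, with an expected range of 1100 nM to 7000 nM.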

Compound 3, half-maximal inhibitory concentration: 5340 nM
Beside the measured number, compound 3's estimate is 1.9-fold (0.28 log units) below it; the range from low to high includes it.
By their numbers in this assay, from the lowest: compound 2; then compounds 1 and 3 (each within the scatter of the next).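

In this assay cyclopropyl in place of methyl on the carbonyl carbon, with the rest of the molecule unchanged, weakens inhibition beyond the scatter (a 2.6-fold higher number from compound 2 to compound 3 (0.41 log units; beyond the scatter)). With cyclopropyl there, 2,4-dichlorophenyl and 4-chloro-3-(trifluoromethyl)phenyl on the amide-type nitrogen stay within the scatter (a 1.0-fold higher number from compound 1 to compound 3 (0.01 log units; within the scatter)). Nothing available explains why the carbonyl substituent matters here. Open, from the compounds shown here alone, is how a longer chain such as propanoyl, or an amine, would behave on that carbonyl carbon. Also open, going by these compounds, is whether the two aryl groups would still match with methyl there.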